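The source may hold more compounds than are shown below. What is called first, only, known or untested is meant among the compounds shown, and "the series" means these compounds.

Measured so far in an ADME assay on L6 cells (Rattus norvegicus) for cytotoxicity; a lower number here means a stronger inhibitor, a higher number a weaker inhibitor:
- compound 1 `COc1ccc(N2CCN(C(=O)Cn3cnc([N+](=O)[O-])n3)CC2)cc1`: 133000 nM
- compound 2 `Cc1ccc(N2CCN(C(=O)Cn3cnc([N+](=O)[O-])n3)CC2)cc1`: 148000 nM

Compound 2 gives 148000 nM and compound 1 gives 133000 nM, so the two numbers cannot be told apart. Among the measured compounds shown here, the only measured step, a 1.1-fold higher number from compound 1 to compound 2 (0.05 log units; within the scatter), stays within the scatter. With just these two compounds, the series offers no real spread of values yet.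

The next compound is compound 3 `O=C(Cn1cnc([N+](=O)[O-])n1)N1CCN(c2ncccn2)CC1`, with pyrimidin-2-yl in place of 4-methylphenyl on an amine nitrogen in a ring. The measured step bears on this only in part. For the measured compounds named here, it exchanges a group on the aromatic ring, whereas here the whole aromatic ring is replaced, and no measured compound carries a ring with hetero atoms at this place. That step is small, but it gives only weak support for a small change here, so the range is kept wide. No shift beyond the scatter is expected in this assay, and the expected step is a 1.1-fold higher number from compound 2 to compound 3 (0.06 log units; within the scatter). For compound 3 the estimated value is 170000 nM, with an expected range of 85000 nM to 340000 nM.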

Compound 3, half-maximal inhibitory concentration: 150000 nM
Estimate against measurement, compound 3: 1.1-fold (0.05 log units) above, within the range that was stated.
By their numbers in this assay, from the lowest: compounds 1, 2 and 3 (each within the scatter of the next).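

In this assay, exchanging 4-methylphenyl for pyrimidin-2-yl on the amine nitrogen in the ring gives a 1.0-fold higher number from compound 2 to compound 3 (0.01 log units; within the scatter), and exchanging 4-methoxyphenyl for the same group gives a 1.1-fold higher number from compound 1 to compound 3 (0.05 log units; within the scatter). The earlier step changed only a group on the aromatic ring, whereas these steps replace the ring itself: a six-membered aromatic ring of carbon only gives way to one with 2 hetero atoms and 2 hydrogen-bond acceptors, with no shift beyond the scatter across compounds 1, 2 and 3. No available evidence bears on this result.

On these data alone, all three compounds carry a six-membered aromatic ring at this place, so it remains open whether the same flat response would hold for a simple alkyl chain, a saturated ring such as cyclohexyl, or a benzyl group on this nitrogen. Among the compounds shown here, it is equally open whether a carboxylic acid or a primary amine on the aromatic ring would move the number beyond the scatter, since the series so far shows no change that does.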